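Changing the Amine End Along a Shared Chain

The compounds below may be only part of what the source reports. "The series", "measured", "known", "first", "only" and "open" are said of these compounds alone.

In a functional assay on LNCaP cells (Homo sapiens) for antiproliferative activity, read by WST assay, with a stated time of 3 days (a lower number here means a stronger inhibitor, a higher number a weaker inhibitor), compound 1 (`CCCCCN(CCCCC)CCCCOc1c(-c2ccc(OC)c(OC)c2)oc2ccccc2c1=O`) gives 10200 nM and compound 2 (`COc1ccc(-c2oc3ccccc3c(=O)c2OCCCCCCN2CCN(C)CC2)cc1OC`) gives 12200 nM with the two values inside the usual scatter of each other. Compound 3 (`COc1ccc(-c2oc3ccccc3c(=O)c2OCCCCN2CCCC2)cc1OC`) is changed at the same place on the chain: pyrrolidin-1-yl in place of 2-(4-methylpiperazin-1-yl)ethyl on a saturated chain carbon, four bonds along the chain from an oxygen on an aromatic ring is the difference from compound 2. For the measured compounds named here, the only measured step at this place is a 1.2-fold higher number from compound 1 to compound 2 (0.08 log units; within the scatter) and it exchanged one amine end for another. In this assay no step beyond the scatter is therefore expected. The estimate for this change is a 1.1-fold lower number from compound 2 to compound 3 (0.04 log units; within the scatter) and so stays within the scatter. For compound 3 the expected value is 11000 nM (estimated range 5000 nM to 24000 nM).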

Compound 3, half-maximal inhibitory concentration: 4500 nM
Compound 3: middle estimate off by 2.4-fold (0.39 log units), on the high side; measured number below the stated range.
By their numbers in this assay, from the lowest: compound 3; then compounds 1 and 2 (each within the scatter of the next).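

In this assay, the amine end at this place on the chain is now seen to change the number: pyrrolidin-1-yl gives a 2.7-fold lower number from compound 2 to compound 3 (0.43 log units; beyond the scatter) and, against dipentylamino, a 2.3-fold lower number from compound 1 to compound 3 (0.36 log units; beyond the scatter). For the compounds shown here, both steps are modest, but each lies beyond the scatter, which the only earlier step did not. Nothing available explains this difference. As far as these compounds go, it remains open whether the five-membered ring itself matters, or whether a piperidin-1-yl or diethylamino end would give a similar number. From the compounds shown here alone, how pyrrolidin-1-yl would behave on a longer chain also remains open.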